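The compounds below may be only part of what the source reports. "The series", "measured", "known", "first", "only" and "open" are said of these compounds alone.

Compound 1 `O=C(Nc1cccc(-n2cc(-c3ccncc3)c(-c3ccc(Cl)c(O)c3)n2)c1)Nc1cccc(C(F)(F)F)c1`: 960 nM
Compound 2 `O=C(Nc1cccc(-n2cc(-c3ccncc3)c(-c3ccc(Cl)c(O)c3)n2)c1)Nc1ccc(Cl)c(Cl)c1`: "not determined" (no result reported)
Compound 3 `COc1cc(-c2nn(-c3cccc(NC(=O)Nc4cccc(C(F)(F)F)c4)c3)cc2-c2ccncc2)ccc1Cl`: 310 nM

In a functional assay on SF-295 cells (Homo sapiens) for inhibition, read by sulforhodamine B assay, with a stated time of 48 h (a higher number here means a weaker inhibitor, a lower number a stronger inhibitor), compound 1 gives 960 nM, the highest of the two numbers on hand; compound 3 gives 310 nM, while compound 2 has no result in this assay. Going by the values given here, the only measured step, a 3.1-fold lower number from compound 1 to compound 3 (0.49 log units; beyond the scatter), concerns methyl in place of hydrogen on an oxygen on an aromatic ring, a different place from the change followed here. Compound 4 `O=C(Nc1cccc(-n2cc(-c3ccncc3)c(-c3ccc(Cl)c(O)c3)n2)c1)Nc1cc(C(F)(F)F)cc(C(F)(F)F)c1` differs from compound 1 by trifluoromethyl in place of hydrogen on an aromatic carbon. Among the compounds with values here, no measured step touches that ring, so for compound 4 the expected step is a 1.1-fold lower number from compound 1 to compound 4 (0.03 log units; within the scatter) in this assay, which amounts to nothing beyond the scatter. The estimate for compound 4 is therefore 900 nM, with a range from 300 nM to 2700 nM.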

Compound 4, half-maximal inhibitory concentration: 620 nM
Estimate against measurement, compound 4: 1.5-fold (0.16 log units) above, within the range that was stated.
By their numbers in this assay, from the lowest: compounds 3, 4 and 1 (each within the scatter of the next, the first and the last beyond it).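

In this assay, trifluoromethyl in place of hydrogen on this aromatic carbon, meta to a trifluoromethyl group, gives a 1.5-fold lower number from compound 1 to compound 4 (0.19 log units; within the scatter). For this one pair, then, a group of four heavy atoms can enter here with no change in the number that stands out from the scatter. Nothing on hand gives a reason for this result.

From the compounds shown here alone, whether an amine or a carboxylic acid at this position would shift the number remains open. So does whether the same change would act alike on compound 3.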